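Benzyl for tert-butyl on a Second Dithiocarbamate Core

A few compounds are considered here, and "the series" means these few. Any claim that something is new, unique, unknown or untested is made for them only; others in the source may bear on it.

Of the compounds shown here, three of one series have been measured in a functional assay on MGC-803 cells (Homo sapiens) for inhibition, read by MTT assay, with a stated time of 72 h; a higher number here means a weaker inhibitor, a lower number a stronger inhibitor. Compound 1 `CC(C)(C)OC(=O)N1CCN(C(=S)SCc2cn(Cc3ccc(Cl)c(Cl)c3)nn2)CC1` gives 33700 nM. Compound 2 `O=C(OCc1ccccc1)N1CCN(C(=S)SCc2cn(Cc3ccc(Cl)c(Cl)c3)nn2)CC1` differs from compound 1 by benzyl in place of tert-butyl on an oxygen next to a carbonyl group; compound 2 gives 7140 nM, and the change brought a 4.7-fold lower number from compound 1 to compound 2 (0.67 log units; beyond the scatter). Compound 3 `CC(C)(C)OC(=O)N1CCN(C(=S)SCc2cn(Cc3ccccc3Cl)nn2)CC1` gives 490 nM, and it differs from compound 1 in its core by 2-chlorophenyl in place of 3,4-dichlorophenyl on a saturated chain carbon bound to an aromatic nitrogen, a change that brought a 69-fold lower number from compound 1 to compound 3 (1.84 log units; beyond the scatter). Compound 3 thus has the lowest number of the three, with compound 2 and compound 1 both well beyond the scatter above it.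

Compound 4 `O=C(OCc1ccccc1)N1CCN(C(=S)SCc2cn(Cc3ccccc3Cl)nn2)CC1` has not yet been measured. It differs from compound 3 by benzyl in place of tert-butyl on an oxygen next to a carbonyl group. This is the same change that was made from compound 1 to compound 2, and it sits at the same place on both cores; among the four compounds it occurs twice. In this assay that earlier change gave a modest step beyond the scatter. Whether the step carries over onto the core of compound 3 is not shown by any measured pair, so the expectation rests on that single earlier step and on compound 3 alone.

For compound 4 the expected step is estimated as a 3.3-fold lower number from compound 3 to compound 4 (0.51 log units; beyond the scatter), somewhat smaller than the measured step from compound 1 to compound 2 to allow for the change of core. In this assay compound 4 is therefore expected to give about 150 nM, with a likely range from 40 nM to 600 nM.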

Compound 4, half-maximal inhibitory concentration: 15500 nM
The estimate for compound 4 lay 100-fold (2.01 log units) below the measured number, outside the stated range (above it).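

On the core of compound 3, benzyl in place of tert-butyl on an oxygen next to a carbonyl group did not repeat its earlier effect in this assay, giving a 32-fold higher number from compound 3 to compound 4 (1.50 log units; beyond the scatter), so the two occurrences of this change disagree in direction: the same change on two cores in this assay, a 4.7-fold lower number (0.67 log units; beyond the scatter) from compound 1 to compound 2 and a 32-fold higher number (1.50 log units; beyond the scatter) from compound 3 to compound 4, 150-fold (2.17 log units) apart, beyond the scatter of two such steps. The other change depends in the same way on its partner, as 2-chlorophenyl in place of 3,4-dichlorophenyl gives a 2.2-fold higher number from compound 2 to compound 4 (0.34 log units; beyond the scatter) when benzyl rather than tert-butyl is present: the same change on two cores in this assay, a 69-fold lower number (1.84 log units; beyond the scatter) from compound 1 to compound 3 and a 2.2-fold higher number (0.34 log units; beyond the scatter) from compound 2 to compound 4, 150-fold (2.17 log units) apart, beyond the scatter of two such steps. In these four compounds, then, neither change can be carried from one core to the other as a fixed step, but the set shows neither why the two places depend on each other nor whether the same holds for any other group.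

The compounds shown leave open whether the low number of compound 3, 490 nM, belongs only to the pairing of tert-butyl with 2-chlorophenyl. Nor do they tell whether an ethyl or an isopropyl on that oxygen, or a 4-chlorophenyl or an unsubstituted phenyl on the saturated chain carbon, would follow compound 3 or compound 4.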